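Trading a Sulfonamide for a Methylamide on the Same Ring

The compounds below may be only part of what the source reports. "The series", "measured", "known", "first", "only" and "open" are said of these compounds alone.

Compound 1, `COc1ccc(-c2cc(-c3ccc(S(N)(=O)=O)cc3)cnc2N)cn1`, stands at the limit of < 7 mL.min-1.g-1 in this assay, at which 2 of the 3 values shown sit, in an in vitro ADME assay on microsomes from liver (Homo sapiens) for metabolic stability; a higher number here means faster removal of the compound, a lower number slower removal. Its own reading there is < 7 mL.min-1.g-1, which is a limit of the assay rather than a number. Compound 3, `COc1ccc(-c2cc(-c3cccc(C(N)=O)c3)cnc2N)cn1`, also returns a limit in this assay, < 7 mL.min-1.g-1. Compound 2, `COc1ccc(-c2cnc(N)c(-c3ccc(OC)nc3)c2)cn1`, gives a measured value of 19.9 mL.min-1.g-1 in this assay. Compound 4, `CNC(=O)c1ccc(-c2cnc(N)c(-c3ccc(OC)nc3)c2)cc1`, differs from compound 1 by methylcarbamoyl in place of sulfamoyl on an aromatic carbon. Going by the values given here, no measured pair in this set shows a change of this kind, so the size of the step is uncertain; compound 4 is expected to be removed somewhat faster than compound 1, a step of an at least 1.5-fold higher number from compound 1 to compound 4 (0.19 log units; that floor lies within the scatter) that may stay within the usual scatter. Compound 4 is therefore estimated at 11 mL.min-1.g-1 in this assay, within 5 mL.min-1.g-1 to 25 mL.min-1.g-1.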

Compound 4, intrinsic clearance in microsomes in the Homo sapiens assay: < 7 mL.min-1.g-1
Compound 4: no number, only a limit; the forecaster's own chance of this, stated with the estimate: 35%; middle value at least 1.5-fold (0.19 log units) from the limit.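

In the Homo sapiens assay compound 1 gives < 7 mL.min-1.g-1, which is a limit of the assay and not a number. In the Homo sapiens assay compound 4 gives < 7 mL.min-1.g-1, which is also a limit of the assay and not a number. The step between them cannot be read. The compounds shown leave open how far methylcarbamoyl in place of sulfamoyl shifts the rate of removal. In a physicochemical assay for solubility, read by nephelometry, in phosphate buffer, measured as kinetic solubility, at pH 6.5 (a higher number here means a more soluble compound, a lower number a less soluble compound), compound 1 gives 12.5 ug/mL. In the physicochemical assay compound 4 gives 50 ug/mL. In the physicochemical assay methylcarbamoyl in place of sulfamoyl goes with a 4.0-fold higher number from compound 1 to compound 4 (0.60 log units; beyond the scatter).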